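Ether to fluorinated pyrazole on the same chain carbon

This account rests on a few compounds, and the source may have more. Where it says the series, first, only, none or still open, it means among the compounds named here.

compound 1 `CS(=O)(=O)Cc1cccc2c1CCC2c1ncc[nH]1` 84 nM; compound 2 `CCOCc1cccc2c1CCC2c1ncc[nH]1` 62 nM; compound 3 `c1cc(Cn2cccn2)c2c(c1)[C@H](c1ncc[nH]1)CC2` 32 nM.

In a functional assay on CHO cells for agonist activity at Alpha-1A adrenergic receptor (Homo sapiens), read by fluorescence and calcium flux (a higher number here means that more compound is needed for the effect, a lower number that less compound is needed), compound 2 gives 62 nM, the second highest of the three numbers; compound 1 is nearest and compound 3 furthest, both within the scatter. For the measured compounds named here, the one measured step, a 1.4-fold lower number from compound 1 to compound 2 (0.13 log units; within the scatter), shows that exchanging one small group for another on this chain carbon hardly moved the number. Compound 4 `Fc1ccn(Cc2cccc3c2CCC3c2ncc[nH]2)n1` carries 3-fluoro-1H-pyrazol-1-yl in place of ethoxy on a saturated chain carbon bound to an aromatic carbon. Compound 3 also bears a pyrazolyl group on a saturated chain carbon bound to an aromatic carbon and gives 32 nM, close to compound 2. Because the step of a 1.4-fold lower number from compound 1 to compound 2 (0.13 log units; within the scatter) was flat and compound 3 sits near compound 2, no shift beyond the scatter is expected for compound 4, estimated at 40 nM with a range of 15 nM to 110 nM. That expectation corresponds to a step of a 1.6-fold lower number from compound 2 to compound 4 (0.19 log units; within the scatter).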

Compound 4, half-maximal effective concentration in the Alpha-1A adrenergic receptor assay: 17 nM
The estimate for compound 4 lay 2.4-fold (0.37 log units) above the measured number, and the stated range covers the measured number.
By their numbers in the Alpha-1A adrenergic receptor assay, from the lowest: compounds 4, 3, 2 and 1 (each within the scatter of the next, the first and the last beyond it).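

In the Alpha-1A adrenergic receptor assay the earlier exchange of one small group for another on this chain carbon, a 1.4-fold lower number from compound 1 to compound 2 (0.13 log units; within the scatter), stayed within the scatter, but with the 3-fluoro-1H-pyrazol-1-yl group compound 4 gives 17 nM, a modest shift: a 3.6-fold lower number from compound 2 to compound 4 (0.56 log units; beyond the scatter) and a 4.9-fold lower number from compound 1 to compound 4 (0.69 log units; beyond the scatter). In a physicochemical assay for lipophilicity, at pH 7.4 (a higher number here means a more lipophilic compound, a lower number a more polar compound), the same change gives a number 0.30 log units higher from compound 2 to compound 4 (within the scatter). In the physicochemical assay compound 2 gives 2.1 and compound 4 gives 2.4. Nothing available accounts for the drop in the receptor number. Still open, from the compounds shown here alone, is whether the fluorine on the pyrazole contributes to this drop, and whether an amine or a carboxylic acid on the same chain carbon would lower the number further.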